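A New Side Chain on the Core of Compound 1

The compounds below may be only part of what the source reports. "The series", "measured", "known", "first", "only" and "open" are said of these compounds alone.

- Compound 1 `CC(C)=CCC[C@H](C)c1ccc(C)c2c1OCN(CCCCCO)C2`: 6900 nM
- Compound 2 `CC(C)=CCC[C@H](C)c1ccc(C)c(CNCCCCC(=O)O)c1O`: > 20000 nM, a limit and not a number

Within the data shown here, in a functional assay on MCF7 cells (Homo sapiens) for inhibition, read by MTT assay, with a stated time of 72 h (a lower number here means a stronger inhibitor, a higher number a weaker inhibitor), compound 1 gives 6900 nM, the only exact number available so far. Compound 2 reports only a limit, so it offers no second number for comparison.

Compound 3 `CCOC(CCN1COc2c([C@@H](C)CCC=C(C)C)ccc(C)c2C1)OCC` keeps the core of compound 1 but alters the chain on its ring nitrogen: diethoxymethyl in place of 3-hydroxypropyl on a saturated chain carbon, two bonds along the chain from an amine nitrogen in a ring. Here, diethoxymethyl stands in place of 3-hydroxypropyl on a saturated chain carbon, two bonds along the chain from an amine nitrogen in a ring. Among the measured compounds shown here, no measured pair shows what this change does, so the forecast is uncertain. No change beyond the usual scatter is expected in this assay, and the estimated step is a 1.3-fold higher number from compound 1 to compound 3 (0.12 log units; within the scatter). The expected value for compound 3 is 9000 nM. Its estimated range runs from 3500 nM to 20000 nM.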

Compound 3, half-maximal inhibitory concentration: 13200 nM
Compound 3: middle estimate off by 1.5-fold (0.17 log units), on the low side; the range from low to high includes it.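

Placing diethoxymethyl where 3-hydroxypropyl stood, on a saturated chain carbon two bonds along the chain from an amine nitrogen in a ring, gives a 1.9-fold higher number from compound 1 to compound 3 (0.28 log units; within the scatter) in this assay. Among these compounds, this is the first measured pair at this position, and it shows that compounds 1 and 3 cannot be told apart in this assay, even though the entering group has more heavy atoms and no hydrogen-bond donor. Nothing measured here gives a reason for this result.

As far as these compounds go, whether an amide or a phenyl ring in place of diethoxymethyl at this same place would also stay within the scatter remains open. Among the compounds shown here, compound 2 gives > 20000 nM, which is a limit and not a number, so it offers no step to set beside this one.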